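Working notes: ether variation in a two-compound series

This account rests on a few compounds, and the source may have more. Where it says the series, first, only, none or still open, it means among the compounds named here.

Measured so far:
compound 1 `COc1ccc(-c2ccn(CCC(C)C)c(=O)c2C#N)cc1F` gives 160% in a functional assay on CHO cells for positive allosteric modulation of metabotropic glutamate receptor 2 (Homo sapiens), read by scintillation counting and GTPgammaS binding, with a stated time of 30 min; on this read-out lower numbers stand for smaller maximal responses and higher numbers for larger maximal responses
compound 2 `COc1ccc(-c2ccn(CCC(C)C)c(=O)c2C#N)cc1Cl` gives 200% in this assay

Among the compounds with values here, compound 2 stands as the higher of the two numbers in this assay; its nearest neighbour is compound 1, and the single measured step, a number 40 percentage points higher from compound 1 to compound 2 (beyond the scatter), is a change of chloro in place of fluoro on an aromatic carbon. Within the data shown here, that is the only step known.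

Compound 3 `CC(C)CCn1ccc(-c2ccc(OC3CCOCC3)c(Cl)c2)c(C#N)c1=O` is not yet measured. It differs from compound 2 by oxan-4-yl in place of methyl on an oxygen on an aromatic ring. Among the measured compounds shown here, the measured step concerns the halogen on the aromatic ring and leaves the oxygen substituent untouched, so no measured step bears on the change from compound 2 to compound 3. There is therefore no basis in the numbers for expecting a shift in either direction, and the working assumption is no step beyond the scatter.

Compound 3 is expected to give about 190% in this assay, within 140% to 240%, taking compound 2 at 200% as the only anchor. The estimate amounts to a number 10 percentage points lower from compound 2 to compound 3 (within the scatter), an expected change of no more than the scatter.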

Compound 3, largest response reached (Emax), in percent of the reference or control that the assay uses: 197%
The estimate for compound 3 lay 7 percentage points below the measured number, and the stated range covers the measured number.
By their numbers in this assay, from the lowest: compound 1; then compounds 3 and 2 (each within the scatter of the next).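

Working notes on the oxygen substituent: in this assay, the change from methoxy to (oxan-4-yl)oxy gives a number 3 percentage points lower from compound 2 to compound 3 (within the scatter). Within the data shown here, the one earlier step concerned only the halogen, so this is the first reading at the oxygen on the aromatic ring, and it shows that, with chloro held constant, a single methyl can give way to a substituent of six heavy atoms, with a six-membered non-aromatic ring and one hydrogen-bond acceptor, without a shift beyond the scatter on this read-out. No supporting data bear on why the maximal response holds across this change.

The compounds shown leave open whether oxan-4-yl on this oxygen would give the same outcome with fluoro on the aromatic ring, as in compound 1, so it remains unknown whether the two changes act independently. They also leave open whether the tolerance extends to other groups on this oxygen, such as a piperidin-4-yl amine, a carboxylic acid or a longer alkyl chain, and how any of these changes affects anything other than the maximal response.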